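Amide aryl variation in a thiazole ester series

This account rests on a few compounds, and the source may have more. Where it says the series, first, only, none or still open, it means among the compounds named here.

Measured so far:
compound 1, `CCOC(=O)c1sc(-c2cccc(NC(=O)c3ccc(C(F)(F)F)cc3)c2)nc1Nc1ccc(N2CCN(C)CC2)cc1`: 33%
compound 2, `CCOC(=O)c1sc(-c2cccc(NC(=O)c3ccccc3F)c2)nc1Nc1ccc(N2CCN(C)CC2)cc1`: 89.8%
compound 3, `CCOC(=O)c1sc(-c2cccc(NC(=O)c3ccc(C#N)cc3)c2)nc1Nc1ccc(N2CCN(C)CC2)cc1`: 79.1%

In a functional assay on Raji cells (Homo sapiens) for antiproliferative activity, read by CCK-8 assay, with a stated time of 72 h, tested at 40 uM (on this read-out lower numbers stand for less inhibition and higher numbers for more inhibition at the one concentration tested (going by the name of the read-out)), compound 3 stands second highest of the three, below compound 2 and far above compound 1. Compound 4, `CCOC(=O)c1sc(-c2cccc(NC(=O)c3ccc(F)c(Cl)c3)c2)nc1Nc1ccc(N2CCN(C)CC2)cc1`, is not yet measured; it differs from compound 3 by 3-chloro-4-fluorophenyl in place of 4-cyanophenyl on a carbonyl carbon. Among the compounds with values here, the steps that bear on this place are a number 46.1 percentage points higher from compound 1 to compound 3 (beyond the scatter) and a number 10.7 percentage points lower from compound 2 to compound 3 (beyond the scatter), showing that changes of the aryl on the carbonyl carbon can shift the read-out strongly in either direction. No halogenated aryl of this kind is among the measured compounds, so the direction is uncertain; a modest decrease is expected, a number 14.1 percentage points lower from compound 3 to compound 4 (beyond the scatter). Compound 4 is therefore estimated at 65%, with a range from 30% to 92%.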

Compound 4, a percentage reported as inhibition, at one concentration (the size of the read-out at that concentration, not a potency): 20.7%
Compound 4: middle estimate off by 44.3 percentage points, on the high side; measured number outside the range, below it.
By their numbers in this assay, from the lowest: compound 4; then compound 1; then compound 3; then compound 2.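

In this assay, the aryl on this carbonyl carbon can take the read-out lower than compound 1 did: a number 12.3 percentage points lower from compound 1 to compound 4 (beyond the scatter), alongside a number 58.4 percentage points lower from compound 3 to compound 4 (beyond the scatter). Fluorine on the aryl does not by itself keep the read-out high, as the 2-fluorophenyl and 3-chloro-4-fluorophenyl amides lie far apart: a number 69.1 percentage points lower from compound 2 to compound 4 (beyond the scatter). Nothing measured here accounts for these drops.

Still open, going by these compounds, is whether chlorine or fluorine alone on the phenyl gives the low number seen with compound 4. Also open, on these data alone, is how an amine or a carboxylic acid on this aryl would read.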